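The source may report more compounds than this note shows. Statements on the series, on what has been measured and on what is new or still open speak of the compounds shown alone.

In a functional assay on MDA-MB-231 cells (Homo sapiens) for antiproliferative activity, read by MTT assay, with a stated time of 48 h (a higher number here means a weaker inhibitor, a lower number a stronger inhibitor), compound 1 (`CCCNC(=O)N1CCN(c2ncnc3sc(-c4ccc(N5CCN(C)CC5)cc4)cc23)CC1`) gives 8330 nM, compound 2 (`CN1CCN(c2ccc(-c3cc4c(N5CCN(C(=O)Nc6ccc(OC(F)(F)F)cc6)CC5)ncnc4s3)cc2)CC1`) gives 4600 nM and compound 3 (`CN1CCN(c2ccc(-c3cc4c(N5CCN(C(=O)Nc6ccccc6F)CC5)ncnc4s3)cc2)CC1`) gives 10300 nM. Compound 3 therefore stands at the high end of this small set, a place it shares: a 1.2-fold higher number from compound 1 to compound 3 (0.09 log units; within the scatter) marks no real separation, whereas a 2.2-fold higher number from compound 2 to compound 3 (0.35 log units; beyond the scatter) is modest. Compound 4 (`CN1CCN(c2ccc(-c3cc4c(N5CCN(C(=O)Nc6ccc(Cl)c(C(F)(F)F)c6)CC5)ncnc4s3)cc2)CC1`) has 4-chloro-3-(trifluoromethyl)phenyl in place of 2-fluorophenyl on an amide-type nitrogen. Among the measured compounds shown here, the closest guide is compound 2, with a 2.2-fold higher number from compound 2 to compound 3 (0.35 log units; beyond the scatter) as the only measured step between two phenyl groups there, and a 1.8-fold lower number from compound 1 to compound 2 (0.26 log units; within the scatter) stays within the scatter. The number is therefore expected to fall modestly, with the estimated change being a 2.1-fold lower number from compound 3 to compound 4 (0.31 log units; beyond the scatter). Compound 4 is estimated at 5000 nM, within an expected range of 2200 nM to 11000 nM.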

Compound 4, half-maximal inhibitory concentration: 2220 nM
The estimate for compound 4 lay 2.3-fold (0.35 log units) above the measured number; the measured number falls inside the stated range.
By their numbers in this assay, from the lowest: compound 4; then compounds 2, 1 and 3 (each within the scatter of the next, the first and the last beyond it).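

In this assay no phenyl group on the amide-type nitrogen had yet stood clear of propyl, but the 4-chloro-3-(trifluoromethyl)phenyl group does (a 3.8-fold lower number from compound 1 to compound 4 (0.57 log units; beyond the scatter)). It also separates from both other phenyl groups (a 2.1-fold lower number from compound 2 to compound 4 (0.32 log units; beyond the scatter); a 4.6-fold lower number from compound 3 to compound 4 (0.67 log units; beyond the scatter)), which makes compound 4 the strongest inhibitor of the four. No measured evidence here accounts for this result. The compounds shown leave open whether the chlorine or the trifluoromethyl group alone would give such a step, and how a benzyl group or a longer alkyl chain would read on this nitrogen.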